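A few compounds are considered here, and "the series" means these few. Any claim that something is new, unique, unknown or untested is made for them only; others in the source may bear on it.

Within the data shown here, in an ADME assay on microsomes from liver (Homo sapiens) for metabolic stability, with a stated time of 60 min, tested at 1 uM (on this read-out lower numbers stand for a less stable compound and higher numbers for a more stable compound), compound 3 `COc1cccc(CN2C(=O)C(C3=NS(=O)(=O)c4cc(NS(C)(=O)=O)ccc4N3)=C(O)[C@@H]3[C@H]4CC[C@H](C4)[C@@H]32)c1` gives 61%, the lowest number so far. Compound 1 `CS(=O)(=O)Nc1ccc2c(c1)S(=O)(=O)N=C(C1=C(O)[C@@H]3[C@H]4CC[C@H](C4)[C@@H]3N(Cc3ccccc3)C1=O)N2` gives 80% and compound 2 `CS(=O)(=O)Nc1ccc2c(c1)S(=O)(=O)N=C(C1=C(O)[C@@H]3[C@H]4CC[C@H](C4)[C@@H]3N(Cc3ccccc3F)C1=O)N2` gives 89%. Both of these gaps to compound 3 lie beyond the scatter. Compound 4 `CS(=O)(=O)Nc1ccc2c(c1)S(=O)(=O)N=C(C1=C(O)[C@@H]3[C@H]4CC[C@H](C4)[C@@H]3N(Cc3ccc(F)c(F)c3F)C1=O)N2` differs from compound 3 by one change, 2,3,4-trifluorophenyl in place of 3-methoxyphenyl on a saturated chain carbon bound to an amide-type nitrogen in a ring. Among the measured compounds shown here, two measured steps with the methoxy entering bear on this, a number 19 percentage points lower from compound 1 to compound 3 (beyond the scatter) and a number 28 percentage points lower from compound 2 to compound 3 (beyond the scatter), while the single fluoro step, a number 9 percentage points higher from compound 1 to compound 2 (within the scatter), stays small. For the measured compounds named here, no measured compound carries the new group. A rise in this assay is expected, of modest size, with the expected step being a number 23 percentage points higher from compound 3 to compound 4 (beyond the scatter). For compound 4 the estimate is 84%, within an expected range of 66% to 96%.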

Compound 4, percent of the compound remaining: 100%
Beside the measured number, compound 4's estimate is 16 percentage points below it; the measured number lies above the stated range.
By their numbers in this assay, from the lowest: compound 3; then compounds 1 and 2 (each within the scatter of the next); then compound 4.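

At this position in this assay, 2,3,4-trifluorophenyl stands clear of every other group shown, with a number 39 percentage points higher from compound 3 to compound 4 (beyond the scatter) and a number 20 percentage points higher from compound 1 to compound 4 (beyond the scatter) and also a number 11 percentage points higher from compound 2 to compound 4 (beyond the scatter) as its steps. The single fluoro of compound 2 stayed within the scatter of compound 1, so among these four compounds only the 2,3,4-trifluorophenyl group lifts the number beyond the scatter over plain phenyl.

Which of the three fluorines carry the step stays open, as does how an amine or a carboxylic acid on this phenyl ring would read. Nothing at hand gives a reason for these steps.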